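The source may hold more compounds than are shown below. What is called first, only, known or untested is meant among the compounds shown, and "the series" means these compounds.

In a functional assay on K562 cells (Homo sapiens) for inhibition, read by sulforhodamine B assay, with a stated time of 48 h; a higher number here means a weaker inhibitor of growth, a lower number a stronger inhibitor of growth:
- Compound 1 `CC(C)(C)NCc1c(C(=O)O)nn(-c2ccccc2)c1-c1ccccc1`: > 716000 nM, a limit
- Compound 2 `CC(C)(C)NCc1c(C(=O)O)nn(-c2ccc(Cl)cc2)c1-c1ccc(F)cc1`: > 623000 nM, a limit
- Compound 3 `CC(C)(C)NCc1c(C(=O)O)nn(-c2ccc(Cl)cc2)c1-c1ccc(Br)cc1`: 297000 nM

Compound 3 alone gives an actual number, as the other two results are limits. Compound 4 `CC(C)(C)NCc1c(C(=O)O)nn(-c2ccc(Cl)cc2)c1-c1ccccc1` has not yet been measured. The change is hydrogen in place of bromo on an aromatic carbon. Within the data shown here, the one measured step that bears on it is an at least 2.0-fold lower number from compound 2 to compound 3 (0.32 log units; beyond the scatter), which also involves the bromo. Removing the bromo is therefore expected to raise the number in this assay by a similar size, possibly to a limit. The expected change is a 2.0-fold higher number from compound 3 to compound 4 (0.31 log units; beyond the scatter). For compound 4 the estimate is 600000 nM, with an expected range of 300000 nM to 1000000 nM.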

Compound 4, concentration for 50% growth inhibition: > 652000 nM
Compound 4 was reported as a limit (the forecaster's own chance of this, stated with the estimate: 65%); middle value at least 1.0-fold (0.03 log units) away from the limit.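

In this assay, the change from 4-bromophenyl to phenyl gives an at least 2.1-fold higher number from compound 3 to compound 4 (0.34 log units; beyond the scatter), so among these compounds only the one carrying the bromo reaches a real number. Compound 4 gives > 652000 nM, a limit, even though it keeps the chloro that compound 3 also carries. The steps to compound 4 from compound 1 and from compound 2 cannot be read: both ends are limits.

From the compounds shown here alone, whether an iodo or a methoxy at this place would also give a real number stays open. Also open, going by these compounds, is what the bromo gives in a compound without the chloro.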